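Swapping one aromatic ring for another at the limit

The source may report more compounds than this note shows. Statements on the series, on what has been measured and on what is new or still open speak of the compounds shown alone.

In a functional assay on MIA PaCa-2 cells (Homo sapiens) for antiproliferative activity, read by MTT assay, with a stated time of 24 h (a higher number here means a weaker inhibitor, a lower number a stronger inhibitor), compound 1 (`COc1ccc(-c2noc(C3CCNCC3)n2)cc1OC1CCCC1`) gives 540 nM as its reading. Compound 2 (`COc1ccc(-c2noc(-c3cccnc3)n2)cc1OC1CCCC1`) reads > 1000000 nM and this is a limit of the assay, not a number. Compound 2 therefore offers no exact starting point for what follows.

Putting 4-chlorophenyl in place of pyridin-3-yl (4-chlorophenyl in place of pyridin-3-yl on an aromatic carbon) turns compound 2 into compound 3 (`COc1ccc(-c2noc(-c3ccc(Cl)cc3)n2)cc1OC1CCCC1`). Going by the values given here, compound 3 still carries a six-membered aromatic ring in that place, and the one measured step that bears on it is an at least 1800-fold higher number from compound 1 to compound 2 (3.26 log units; beyond the scatter) with pyridin-3-yl in place of piperidin-4-yl on an aromatic carbon, so most of that large rise is expected to stay in compound 3. Any change is expected to run toward a lower number, and a reading that again reaches the limit would be no surprise. The estimated step is an at least 5.0-fold lower number from compound 2 to compound 3 (0.69 log units; beyond the scatter) and it remains small beside the measured one. Compound 3 is expected to read about 200000 nM with an estimated range from 10000 nM to 1000000 nM in this assay once measured.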

Compound 3, half-maximal inhibitory concentration: 740 nM
Beside the measured number, compound 3's estimate is 270-fold (2.43 log units) above it; the whole stated range lies above it.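

In this assay the reading of compound 2 is a limit of the assay and not a number: the limit of > 1000000 nM in this assay, at which 1 of the 3 values shown sits.

Exchanging pyridin-3-yl for 4-chlorophenyl gives an at least 1300-fold lower number from compound 2 to compound 3 (3.13 log units; beyond the scatter), so a six-membered aromatic ring at this place does not by itself abolish the activity, as the first step alone might have suggested. Set against piperidin-4-yl, 4-chlorophenyl gives a 1.4-fold higher number from compound 1 to compound 3 (0.14 log units; within the scatter), which lies within the scatter, so two very different groups read alike here, and among these three compounds only pyridin-3-yl stands apart.

The change from pyridin-3-yl to 4-chlorophenyl does two things at once, removing a ring nitrogen and adding a chlorine, and a plain phenyl group at this place would be needed to tell which of the two carries the step. On these data alone, how pyridin-4-yl, with its ring nitrogen moved, or a phenyl ring bearing an amine or a carboxylic acid would read also stays open.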